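The source may hold more compounds than are shown below. What is called first, only, known or untested is meant among the compounds shown, and "the series" means these compounds.

Measured so far in a functional assay on ASK cells (Rattus norvegicus) for cytotoxicity, read by sulforhodamine B assay; a higher number here means that more compound is needed for the effect, a lower number that less compound is needed:
compound 1 `C=C1CC[C@@H]2[C@](C)(CO[Si](c3ccccc3)(c3ccccc3)C(C)(C)C)[C@H](OC(C)=O)CC[C@@]2(C)[C@@H]1C/C=C1/C(=O)OC[C@H]1O`: 10.5 uM
compound 2 `C=C1CC[C@@H]2[C@](C)(CO[Si](c3ccccc3)(c3ccccc3)C(C)(C)C)[C@H](O)CC[C@@]2(C)[C@@H]1C/C=C1/C(=O)OC[C@H]1O`: 5.54 uM

Within the data shown here, compound 1 and compound 2 are the only measured pair, and their values lie within the scatter of each other. Compound 3 `C=C1CC[C@@H]2[C@](C)(CO[Si](c3ccccc3)(c3ccccc3)C(C)(C)C)[C@H](OC(C)=O)CC[C@@]2(C)[C@@H]1C/C=C1/C(=O)OC[C@H]1OC(C)=O` has one change from compound 1: acetyl in place of hydrogen on an oxygen on a saturated carbon. This is acetyl in place of hydrogen on an oxygen on a saturated carbon, or hydroxy to acetoxy. Among the measured compounds shown here, the one measured step that bears on it is a 1.9-fold lower number from compound 1 to compound 2 (0.28 log units; within the scatter), which exchanges hydrogen and acetyl on a different oxygen, in the opposite sense. That step stays within the scatter, so no step beyond the scatter is expected in this assay, although a single pair is thin support. For compound 3 the expected value is 12 uM, with an estimated range of 5 uM to 28 uM. The estimated step is a 1.1-fold higher number from compound 1 to compound 3 (0.06 log units; within the scatter).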

Compound 3, concentration for half-maximal effect: 32.8 uM
Beside the measured number, compound 3's estimate is 2.7-fold (0.44 log units) below it; measured number outside the range, above it.
By their numbers in this assay, from the lowest: compounds 2 and 1 (each within the scatter of the next); then compound 3.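

In this assay, among these compounds, hydroxy to acetoxy at this position, on an oxygen on a saturated carbon, gives a 3.1-fold higher number from compound 1 to compound 3 (0.49 log units; beyond the scatter), a modest change and the only step that lies beyond the scatter. The exchange of hydrogen and acetyl on the other oxygen, a 1.9-fold lower number from compound 1 to compound 2 (0.28 log units; within the scatter), stays within the scatter, so the acetyl exchange cannot be treated as a single effect for both oxygens, although each oxygen rests on one pair. No measurement is available that accounts for this step.

From the compounds shown here alone, whether the step belongs to acetyl specifically or would also appear with another group on this oxygen remains open, and a methyl ether or a longer acyl chain such as butyryl would test this. Going by these compounds, whether an amine in place of the hydroxy would give a number near that of compound 1 also remains open.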